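Cytotoxicity notes: trifluoromethylphenyl replacing methoxyphenyl in the series

The source may report more compounds than this note shows. Statements on the series, on what has been measured and on what is new or still open speak of the compounds shown alone.

Measured compounds, with values in an ADME assay on HeLa cells (Homo sapiens) for cytotoxicity, read by MTT assay; a higher number here means a weaker inhibitor, a lower number a stronger inhibitor:
- compound 1 `N#Cc1c(-c2ccccc2)c(C#N)c(=O)n(/N=C/c2cn(-c3ccccc3)nc2-c2ccccc2)c1N`: > 200 ug/mL
- compound 2 `COc1ccc(-c2c(C#N)c(N)n(/N=C/c3cn(-c4ccccc4)nc3-c3ccccc3)c(=O)c2C#N)cc1`: > 200 ug/mL
- compound 3 `N#Cc1c(-c2cccc([N+](=O)[O-])c2)c(C#N)c(=O)n(/N=C/c2cn(-c3ccccc3)nc2-c2ccccc2)c1N`: > 200 ug/mL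

In this assay compound 2 stands only at a limit, > 200 ug/mL. Compound 1 and compound 3 likewise sit at limits, so all three values rest at the limit of > 200 ug/mL in this assay, at which 3 of the 3 values shown sit. The measured steps are therefore unreadable in size: a step that the two limits leave unreadable from compound 1 to compound 2, a step that the two limits leave unreadable from compound 1 to compound 3 and a step that the two limits leave unreadable from compound 2 to compound 3.

Compound 4 `N#Cc1c(-c2ccccc2C(F)(F)F)c(C#N)c(=O)n(/N=C/c2cn(-c3ccccc3)nc2-c2ccccc2)c1N` differs from compound 2 by 2-(trifluoromethyl)phenyl in place of 4-methoxyphenyl on an aromatic carbon. Within the data shown here, none of the measured steps gives a readable size, so the step that the limit leaves unreadable from compound 2 to compound 4 is expected to stay without a readable direction, most likely ending again at the limit. Compound 4 is estimated at 250 ug/mL, with a range from 100 ug/mL to 600 ug/mL.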

Compound 4, half-maximal inhibitory concentration: > 200 ug/mL
Compound 4 gave a limit, no number (the forecaster's own chance of this, stated with the estimate: 85%); the middle value does not contradict the limit.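

Compound 4 sits at a limit, as do compound 1, compound 2 and compound 3, so no step to compound 4 can be read in this assay: the limit of > 200 ug/mL in this assay, at which 4 of the 4 values shown sit.

The compounds shown leave open whether changing the phenyl group on the shared core alters cytotoxicity at all.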